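The compounds below may be only part of what the source reports. "The series", "measured", "known", "first", "only" and "open" are said of these compounds alone.

Three compounds have entries in a functional assay on HepG2 cells (Homo sapiens) for cytotoxicity, read by sulforhodamine B assay, with a stated time of 48 h (on this read-out lower numbers stand for stronger inhibition of growth and higher numbers for weaker inhibition of growth), and only one of them has a number. Compound 2 `Cc1nn(-c2ccccc2)c(Oc2ccc(-c3nc4cc(C(=O)O)ccc4[nH]3)cc2)c1/C=N/Nc1ccccc1` gave 37200 nM in that test. Compound 1 `Cc1nn(-c2ccccc2)c(Sc2ccc(-c3nc4cc([N+](=O)[O-])ccc4[nH]3)cc2)c1/C=N/NC(N)=O` is recorded as "not determined" (no result reported) and so offers no comparison. Compound 3 `COc1ccc(N/N=C/c2c(C)nn(-c3ccccc3)c2Oc2ccc(-c3nc4cc(C(N)=O)ccc4[nH]3)cc2)cc1` is in the same position: compound 3 is recorded as "not determined" (no result reported) and has no place on the scale, so the step away from it has no measured starting point. Compound 4 `Cc1nn(-c2ccccc2)c(Oc2ccc(-c3nc4cc(C(N)=O)ccc4[nH]3)cc2)c1/C=N/NC(N)=S` keeps the rest of compound 3 and differs on an amine nitrogen whose other neighbour is a double-bonded nitrogen, where the change is a group of 3 heavy atoms (1 carbon, 1 nitrogen, 1 sulfur; no ring) in place of a group of 8 heavy atoms (7 carbon, 1 oxygen; one six-membered aromatic ring of carbon only), on an amine nitrogen in full. Going by the values given here, no measured step shows what such an exchange does in this assay, so no step beyond the usual scatter is expected in either direction. The only anchor for that expectation is compound 2 at 37200 nM on this read-out. It is estimated that compound 4 will give 35000 nM within an expected range of 10000 nM to 100000 nM when it is tested.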

Compound 4, concentration for 50% growth inhibition: 37500 nM
For compound 4 the middle estimate is 1.1-fold (0.03 log units) below the measured one; measured number inside the range.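

Going by these compounds alone, compound 3 is recorded as "not determined" (no result reported) in this assay, so no step to compound 4 can be read. The compounds shown leave open what replacing the 4-methoxyphenyl on that amine nitrogen does to growth inhibition. No supporting evidence bears on this result.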